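A few compounds are considered here, and "the series" means these few. Any claim that something is new, unique, unknown or untested is made for them only; others in the source may bear on it.

Three related compounds have been measured so far, all sharing a long saturated chain joined through an amide to a threonine-derived centre that carries a second amide bearing an aromatic ring. Compound 1 is `CCCCCCCCCCCCCCNC(=O)[C@@H](NC(=O)c1cccs1)[C@@H](C)O`. In a functional assay on MCF7 cells (Homo sapiens) for cytotoxicity, read by MTT assay, with a stated time of 48 h (on this read-out higher numbers stand for weaker inhibition and lower numbers for stronger inhibition), compound 1 gives 36100 nM. Compound 2, `CCCCCCCCCCCCCCNC(=O)[C@@H](NC(=O)c1cc2ccccc2o1)[C@@H](C)O`, differs from compound 1 in one place: 1-benzofuran-2-yl in place of thiophen-2-yl on a carbonyl carbon. That change made a 1.5-fold lower number from compound 1 to compound 2 (0.19 log units; within the scatter). Compound 3, `CCCCCCCCCCCCCCCCCCNC(=O)[C@@H](NC(=O)c1cccs1)[C@@H](C)O`, keeps the aromatic ring of compound 1 but changes the chain: butyl in place of hydrogen on a saturated chain carbon, ten or more bonds along the chain from an amide-type nitrogen. In this assay compound 3 gives 25700 nM, which is a 1.4-fold lower number from compound 1 to compound 3 (0.15 log units; within the scatter). Compound 2 gives 23400 nM, a number that sits within the scatter of the result for compound 3.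

Compound 4, `CCCCCCCCCCCCCCCCCCNC(=O)[C@@H](NC(=O)c1cc2ccccc2o1)[C@@H](C)O`, has not yet been measured. It stands to compound 3 as compound 2 stands to compound 1: 1-benzofuran-2-yl in place of thiophen-2-yl on a carbonyl carbon. The place of this change is worded identically in both pairs, so it is the same change made on a different core; how the two cores differ is given above as the chain change from compound 1 to compound 3. Because the earlier instance of this change gave only a 1.5-fold lower number from compound 1 to compound 2 (0.19 log units; within the scatter), a step of similar size is expected here, namely a 1.5-fold lower number from compound 3 to compound 4 (0.18 log units; within the scatter). On that basis compound 4 is estimated to give 17000 nM, with a plausible range from 8000 nM to 40000 nM.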

Compound 4, half-maximal inhibitory concentration: 126000 nM
Estimate against measurement, compound 4: 7.4-fold (0.87 log units) below; measured number outside the range, above it.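

In this assay, the change from thiophen-2-yl to 1-benzofuran-2-yl did not carry over from one core to the other. On the core with the added butyl it gave a 4.9-fold higher number from compound 3 to compound 4 (0.69 log units; beyond the scatter), which does not match the earlier instance: the same change on two cores in this assay, a 1.5-fold lower number (0.19 log units; within the scatter) from compound 1 to compound 2 and a 4.9-fold higher number (0.69 log units; beyond the scatter) from compound 3 to compound 4, 7.6-fold (0.88 log units) apart, beyond the scatter of two such steps Read the other way, adding the butyl to the chain gave a 5.4-fold higher number from compound 2 to compound 4 (0.73 log units; beyond the scatter) once the 1-benzofuran-2-yl was in place, and this too fails to match what the same chain change did with thiophen-2-yl: the same change on two cores in this assay, a 1.4-fold lower number (0.15 log units; within the scatter) from compound 1 to compound 3 and a 5.4-fold higher number (0.73 log units; beyond the scatter) from compound 2 to compound 4, 7.6-fold (0.88 log units) apart, beyond the scatter of two such steps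

So in this small set the effect of each change depends on the other, and a step measured on one core was a poor guide to the same step on the other. This rests on a single square of four compounds in one assay, however, and it shows neither why the two changes interact nor that 1-benzofuran-2-yl is generally unfavourable with long chains.

The compounds shown leave open whether a chain of intermediate length, or a longer chain than that in compound 3, would follow the same pattern. They also leave open how another ring on the carbonyl, such as phenyl or furan-2-yl, would behave on these two cores.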